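Methylating the ring nitrogen of compound 3

The source may report more compounds than this note shows. Statements on the series, on what has been measured and on what is new or still open speak of the compounds shown alone.

Measured compounds and their values in a functional assay on LS174T cells (Homo sapiens) for inhibition, with a stated time of 4 days, tested at 10 uM; on this read-out lower numbers stand for a weaker effect and higher numbers for a stronger effect at the one concentration tested:
compound 1, `Cc1ccc(C)n1-c1ccc(C#Cc2c(F)cccc2F)cc1`, gives 78.8%
compound 2, `Nc1ccnc2cc(C#Cc3c(F)cccc3F)ccc12`, gives 97.7%
compound 3, `Fc1cccc(F)c1C#Cc1ccc2cn[nH]c2c1`, gives 97%

Compound 3 stands second highest of the three numbers. Its nearest neighbour is compound 2, whose number lies a little higher, within the scatter, so the two cannot be told apart. Its furthest neighbour is compound 1, whose number lies well below, beyond the scatter. All three compounds share the same diaryl alkyne with a difluorinated ring; they differ only in the ring on the other side.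

Compound 4, `Cn1ncc2ccc(C#Cc3c(F)cccc3F)cc21`, has not yet been measured. It differs from compound 3 in one place: methyl in place of hydrogen on an aromatic nitrogen. The change sits on an aromatic nitrogen of a five-membered aromatic ring with 2 nitrogen, part of a fused or bridged system of two rings, next to the ring nitrogen.

For the measured compounds named here, no step between measured compounds shows what this change does. Compound 3 lies near the top of what this read-out can give, so the expected step is downward, if anything; a modest fall beyond the scatter is the expectation, with the chance of none at all. For compound 4 the expected value in this assay is 82%, between 55% and 98%, which means an expected step of a number 15 percentage points lower from compound 3 to compound 4 (beyond the scatter).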

Compound 4, a percentage reported as inhibition, at one concentration (the size of the read-out at that concentration, not a potency): 98.1%
Compound 4: middle estimate off by 16.1 percentage points, on the low side, and the stated range ends below it.
By their numbers in this assay, from the lowest: compound 1; then compounds 3, 2 and 4 (each within the scatter of the next).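

In this assay, methyl in place of hydrogen on an aromatic nitrogen gives a number 1.1 percentage points higher from compound 3 to compound 4 (within the scatter) and so leaves the read-out unchanged within its usual noise. For the compounds shown here, this is the first sign that the hydrogen on this ring nitrogen of compound 3 is not required for a strong effect at the one concentration tested, and that a small group can sit there. Nothing available here explains why this swap is tolerated.

The compounds shown leave open whether this nitrogen would accept something larger than methyl, such as a longer chain or a chain ending in an amine or a carboxylic acid. Going by these compounds, compound 3 and compound 4 both lie near the top of the read-out at a single concentration, and whether one would give a stronger or weaker effect than the other at a different concentration also remains open.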